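This account rests on a few compounds, and the source may have more. Where it says the series, first, only, none or still open, it means among the compounds named here.

Compound 1 `NS(=O)(=O)c1ccc(N2N=C(c3ccc(Oc4ccccc4)cc3)CC2c2ccccc2)cc1` was tested in an ADME assay on MT4 cells (Homo sapiens) for cytotoxicity, read by MTT assay, with a stated time of 96 h (on this read-out lower numbers stand for higher toxicity in this test and higher numbers for lower toxicity in this test), where compound 1 gives 42000 nM. A related compound, compound 2 `NS(=O)(=O)c1ccc(N2N=C(c3ccc(OCc4ccccc4)cc3)CC2c2ccccc2F)cc1`, was measured in the same way; in this assay compound 2 gives 39000 nM, and the two numbers lie within the scatter of each other, so neither stands apart. Compound 3 `NS(=O)(=O)c1ccc(N2N=C(c3ccc(Oc4ccccc4)cc3)CC2c2ccc(Cl)cc2)cc1` has not yet been measured. It differs from compound 1 by chloro in place of hydrogen on an aromatic carbon. Going by the values given here, with no comparable measured step to draw on, the change is expected to shift this assay by a 1.2-fold lower number from compound 1 to compound 3 (0.08 log units; within the scatter), a step not beyond the scatter. Compound 3 is therefore estimated at 35000 nM, within a range from 15000 nM to 80000 nM.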

Compound 3, half-maximal cytotoxic concentration: 9000 nM
Compound 3: the middle estimate sits 3.9-fold (0.59 log units) above what was measured, and the stated range ends above it.
By their numbers in this assay, from the lowest: compound 3; then compounds 2 and 1 (each within the scatter of the next).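

In this assay, the change from phenyl to 4-chlorophenyl gives a 4.7-fold lower number from compound 1 to compound 3 (0.67 log units; beyond the scatter), the first single-place step among these compounds. One added chlorine atom, para to a large group, is thus enough to move the number beyond the scatter, towards higher toxicity in this test. Nothing at hand explains this shift. Going by these compounds, whether fluoro, methoxy or an amine in the same place would move the number this far remains open. So does whether chloro would have the same effect on the core of compound 2.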